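Aryl ether series on the thiazolidinedione core: pyridyl to phenyl

A few compounds are considered here, and "the series" means these few. Any claim that something is new, unique, unknown or untested is made for them only; others in the source may bear on it.

Measured so far in a functional assay for agonist activity at Free fatty acid receptor 1 (Homo sapiens), read by FLIPR, in the presence of a further agent that is not named here; on this read-out lower numbers stand for an effect already at smaller amounts and higher numbers for an effect only at larger amounts of compound:
compound 1 `Cc1ccnc(Oc2ccc(CC3SC(=O)NC3=O)cc2)c1`, 4280 nM
compound 2 `O=C1NC(=O)C(Cc2ccccc2Oc2ccccc2)S1`, 11300 nM
compound 3 `O=C1NC(=O)C(Cc2ccc(Oc3cc(C(F)(F)F)ccn3)cc2)S1`, 237 nM

Compound 1 stands second highest of the three numbers in this assay. Its nearest neighbour is compound 2, whose value sits higher, and the furthest is compound 3, reached by the step of an 18-fold lower number from compound 1 to compound 3 (1.26 log units; beyond the scatter).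

Compound 4 `Cc1cccc(Oc2ccc(CC3SC(=O)NC3=O)cc2)c1` has not yet been measured. It differs from compound 1 as follows: 3-methylphenyl in place of 4-methylpyridin-2-yl on an oxygen on an aromatic ring.

Among the measured compounds shown here, none of the measured steps bears on this change. For the measured compounds named here, the only step recorded, an 18-fold lower number from compound 1 to compound 3 (1.26 log units; beyond the scatter), concerns the trifluoromethyl in place of methyl on an aromatic carbon and leaves the pyridine ring in place; it says nothing about swapping that ring for a carbon-only ring. Compound 2 carries a phenyl on the ether oxygen but also moves the ether to a different position of the shared core, so its value is not a clean comparison. Going by the values given here, with no direct precedent, the step of a 1.2-fold higher number from compound 1 to compound 4 (0.07 log units; within the scatter) is expected to stay within the scatter of compound 1, with a wide range either way.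

The estimate for compound 4 in this assay is 5000 nM, expected between 1500 nM and 16000 nM.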

Compound 4, half-maximal effective concentration: 203 nM
The estimate for compound 4 lay 25-fold (1.39 log units) above the measured number; measured number below the stated range.
By their numbers in this assay, from the lowest: compounds 4 and 3 (each within the scatter of the next); then compound 1; then compound 2.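

In this assay, the exchange of 4-methylpyridin-2-yl for 3-methylphenyl on the ether oxygen gives a 21-fold lower number from compound 1 to compound 4 (1.32 log units; beyond the scatter) and shows that this position responds strongly to the ring itself, not only to the group carried on it. The change puts a ring carbon where the leaving group has its ring nitrogen, and the methyl stays on the ring, so the large step goes with a carbon-only ring and the absence of the hydrogen-bond acceptor counted on the pyridine. Together with an 18-fold lower number from compound 1 to compound 3 (1.26 log units; beyond the scatter) as the other step from the same starting point, compound 1 now has two separate large steps within this one aryl group, one through the ring and one through its substituent. No measurement at hand gives a reason for the size of the ring step.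

Still open, on these data alone, is whether the two steps add up, which a trifluoromethyl in place of the methyl on the carbon-only ring would test. Equally open, as far as these compounds go, is how far the position tolerates other substituents on that ring, such as a chlorine, a methoxy group or a carboxylic acid.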